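Swapping the ketone arm for a chlorinated benzyl group

The source may report more compounds than this note shows. Statements on the series, on what has been measured and on what is new or still open speak of the compounds shown alone.

Within the data shown here, compound 1, `COc1cc(OC)c(-c2coc3cc(OCC(=O)c4cccc(C(F)(F)F)c4)ccc3c2=O)cc1OC`, is one of two compounds measured here. In a functional assay on HCT-116 cells (Homo sapiens) for antiproliferative activity, read by MTT assay, with a stated time of 24 h (a lower number here means a stronger inhibitor, a higher number a weaker inhibitor), compound 1 gives > 10000 nM, which is a limit of the assay rather than a number, as the limit of > 10000 nM in this assay, at which 1 of the 2 values shown sits, records. Compound 2, `COc1cc(OC)c(-c2coc3cc(OCc4ccc(Cl)cc4)ccc3c2=O)cc1OC`, carries a 4-chlorophenyl in place of the (3-(trifluoromethyl)phenyl)carbonyl; in this assay compound 2 gives 4450 nM, and the step is an at least 2.2-fold lower number from compound 1 to compound 2 (0.35 log units; beyond the scatter). Compound 3, `COc1cc(OC)c(-c2coc3cc(OCc4ccccc4Cl)ccc3c2=O)cc1OC`, is not yet measured. It differs from compound 1 by 2-chlorophenyl in place of (3-(trifluoromethyl)phenyl)carbonyl on a saturated chain carbon bound to an oxygen on an aromatic ring. Among the measured compounds shown here, the only measured step that bears on this change is the one from compound 1 to compound 2, which swapped in the closely related 4-chlorophenyl and gave a modest drop. A drop of comparable size is therefore expected, namely an at least 2.0-fold lower number from compound 1 to compound 3 (0.30 log units; that floor lies within the scatter). Compound 3 is estimated at 5000 nM in this assay, within 2000 nM to 15000 nM.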

Compound 3, half-maximal inhibitory concentration: 2450 nM
The estimate for compound 3 lay 2.0-fold (0.31 log units) above the measured number; the measured number falls inside the stated range.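

Compound 3 shows that the gain seen with compound 2 is not confined to the 4-chlorophenyl: with 2-chlorophenyl on the same saturated chain carbon, this assay records an at least 4.0-fold lower number from compound 1 to compound 3 (0.61 log units; beyond the scatter). The placing of the chlorine on the ring makes no clear difference so far, since the comparison reads a 1.8-fold lower number from compound 2 to compound 3 (0.26 log units; within the scatter), and compound 2 and compound 3 cannot be ranked. Compound 1 is fixed only by a limit of the assay, which gives the steps away from it a floor and not a true size: the limit of > 10000 nM in this assay, at which 1 of the 3 values shown sits.

Both chlorinated compounds lose the carbonyl and the trifluoromethyl together, and the compounds shown cannot tell which of these changes counts. As far as these compounds go, whether the chlorine is needed at all also stays open, and a plain unsubstituted phenyl or an amine in its place would bear on that.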